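This account rests on a few compounds, and the source may have more. Where it says the series, first, only, none or still open, it means among the compounds named here.

In an unclassified assay for pharmacokinetics, in phosphate buffer, at pH 7.4, tested at 2 uM, in the presence of a further agent that is not named here (on this read-out lower numbers stand for a shorter-lived compound and higher numbers for a longer-lived compound), compound 1 `C=CC(=O)Nc1ccc(-n2nc(C)c(-c3c(C)ccc4[nH]ncc34)c2C)c(F)c1` gives 0.5 h and compound 2 `C=CC(=O)Nc1ccc(-n2nc(C(C)C)c(-c3c(C)ccc4[nH]ncc34)c2C)c(F)c1` gives 0.333 h. These two numbers lie within the usual scatter of each other, so compound 2 cannot be told apart from compound 1 on this read-out. Compound 3 `C=CC(=O)Nc1ccc(-n2nc(C(C)C)c(-c3c(C)ccc4[nH]ncc34)c2C)c(C)c1` differs from compound 2 in one place: methyl in place of fluoro on an aromatic carbon, which means methyl in place of fluoro on an aromatic carbon. Among the compounds with values here, no measured step makes this swap, so the data offer no direct guide to it. Within the data shown here, the only measured step, a 1.5-fold lower number from compound 1 to compound 2 (0.18 log units; within the scatter), is isopropyl in place of methyl on an aromatic carbon, a change of another group, and it stayed within the scatter. Nothing here points to a shift beyond the scatter, and the expected step, a 1.2-fold higher number from compound 2 to compound 3 (0.08 log units; within the scatter), stays within it. For compound 3 the estimate is 0.4 h, with an expected range from 0.2 h to 0.8 h.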

Compound 3, half-life: 1.78 h
Compound 3: middle estimate off by 4.5-fold (0.65 log units), on the low side, and the stated range ends below it.
By their numbers in this assay, from the lowest: compounds 2 and 1 (each within the scatter of the next); then compound 3.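

Within this assay, the step of a 5.3-fold higher number from compound 2 to compound 3 (0.73 log units; beyond the scatter) comes from methyl in place of fluoro on the aromatic carbon ortho to a large group, and it shows that this position can move the half-life beyond the scatter. The other step, a 1.5-fold lower number from compound 1 to compound 2 (0.18 log units; within the scatter), changed a different place and stayed within the scatter. Fluoro and methyl each hold one heavy atom and have no hydrogen-bond donors or acceptors, so a swap that leaves these counts unchanged is enough for this rise, and nothing measured here explains it.

Still open, from the compounds shown here alone, is whether a rise of this size belongs to methyl itself or would also appear with chloro, methoxy or an amine at this position. Going by these compounds, it is also open whether methyl here would give the same rise with methyl rather than isopropyl elsewhere on the core.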